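Iodo for Methylsulfanyl on the Aryl Urea

The compounds below may be only part of what the source reports. "The series", "measured", "known", "first", "only" and "open" are said of these compounds alone.

Measured compounds:
Compound 1, `O=C(Nc1ccccc1Br)N[C@H]1CC[C@H](Oc2ccc(F)cc2)CC1` — in a functional assay on CRL2813 cells (Homo sapiens) for cytotoxicity, read by sulforhodamine B assay, with a stated time of 5 days (a higher number here means a weaker inhibitor, a lower number a stronger inhibitor), compound 1 gives 7700 nM
Compound 2, `Cc1cccc(NC(=O)N[C@H]2CC[C@H](Oc3ccc(F)cc3)CC2)c1` — in this assay compound 2 gives 14400 nM
Compound 3, `CSc1cccc(NC(=O)N[C@H]2CC[C@H](Oc3ccc(F)cc3)CC2)c1` — in this assay compound 3 gives 11100 nM

Compound 3 has the second highest of the three numbers, yet every step among them lies within the scatter: a 1.9-fold higher number from compound 1 to compound 2 (0.27 log units; within the scatter), a 1.4-fold higher number from compound 1 to compound 3 (0.16 log units; within the scatter), a 1.3-fold lower number from compound 2 to compound 3 (0.11 log units; within the scatter).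

Compound 4 is `O=C(Nc1cccc(I)c1)N[C@H]1CC[C@H](Oc2ccc(F)cc2)CC1`. It differs from compound 3 by iodo in place of methylsulfanyl on an aromatic carbon.

Among the compounds with values here, the steps that bear on this change, a 1.4-fold higher number from compound 1 to compound 3 (0.16 log units; within the scatter) and a 1.3-fold lower number from compound 2 to compound 3 (0.11 log units; within the scatter), both show that swapping one small substituent on the aryl ring for another leaves this assay essentially unmoved. The swap to iodo is therefore expected to give no step beyond the scatter, a 1.2-fold lower number from compound 3 to compound 4 (0.07 log units; within the scatter). Compound 4 is estimated at 9500 nM, in the range 4500 nM to 20000 nM.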

Compound 4, half-maximal inhibitory concentration: 5200 nM
Compound 4: the middle estimate sits 1.8-fold (0.26 log units) above what was measured; low and high end bracket the measured number.
By their numbers in this assay, from the lowest: compounds 4, 1, 3 and 2 (each within the scatter of the next, the first and the last beyond it).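

Among the groups at this ring position, only iodo stands apart from the others in this assay with a 2.1-fold lower number from compound 3 to compound 4 (0.33 log units; beyond the scatter) and with a 2.8-fold lower number from compound 2 to compound 4 (0.44 log units; beyond the scatter) and both steps are modest. Set against the 2-bromophenyl group, however, 3-iodophenyl gives a 1.5-fold lower number from compound 1 to compound 4 (0.17 log units; within the scatter) so those two cannot be told apart here. Nothing measured here accounts for the separation of iodo from methyl and methylsulfanyl.

The compounds shown leave open how chloro would compare with iodo at this position. They also leave open whether an amine or a carboxylic acid there would shift the number further.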